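Trifluoromethyl to (trifluoromethyl)carbonyl on the aryl sulfonamide arm

The source may report more compounds than this note shows. Statements on the series, on what has been measured and on what is new or still open speak of the compounds shown alone.

Compound 1 `CN(C)CC[C@H](CSc1ccccc1)Nc1ccc(S(=O)(=O)NC(=O)c2ccc(N3CCN(Cc4ccccc4-c4ccc(Cl)cc4)CC3)cc2)cc1C(F)(F)F` gives 2460 nM in a functional assay on NCI-H146 cells (Homo sapiens) for cytotoxicity, with a stated time of 48 h, in the presence of a further agent that is not named here; a higher number here means that more compound is needed for the effect, a lower number that less compound is needed. That is the highest number among the three measured compounds; compound 2 `CN(C)CC[C@H](CSc1ccccc1)Nc1ccc(S(=O)(=O)NC(=O)c2ccc(N3CCN(CC4=C(c5ccc(Cl)cc5)CCC4)CC3)cc2)cc1[N+](=O)[O-]` gives 691 nM, the nearest value, and compound 3 `CN(C)CC[C@H](CSc1ccccc1)Nc1ccc(S(=O)(=O)NC(=O)c2ccc(N3CCN(C/C4=C(\c5ccc(Cl)cc5)CCCCCC4)CC3)cc2)cc1[N+](=O)[O-]` gives 200 nM, the furthest, and both gaps from compound 1 lie beyond the scatter. For the measured compounds named here, compounds 2 and 3 differ from compound 1 in more than one place, so no single-point step is available among the measured set.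

Compound 4 `CN(C)CC[C@H](CSc1ccccc1)Nc1ccc(S(=O)(=O)NC(=O)c2ccc(N3CCN(Cc4ccccc4-c4ccc(Cl)cc4)CC3)cc2)cc1C(=O)C(F)(F)F` is the unmeasured analogue of compound 1. The change is (trifluoromethyl)carbonyl in place of trifluoromethyl on an aromatic carbon. Going by the values given here, no measured pair isolates this change, so its effect is unknown from the data at hand. The expectation is a small step in this assay from compound 1 to compound 4, a 1.4-fold lower number from compound 1 to compound 4 (0.14 log units; within the scatter), which may not exceed the scatter. Compound 4 is estimated at 1800 nM, with a range from 600 nM to 5500 nM, the width reflecting the absence of any measured step of this kind.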

Compound 4, half-maximal effective concentration: 2010 nM
Compound 4: the middle estimate sits 1.1-fold (0.05 log units) below what was measured, and the stated range covers the measured number.
By their numbers in this assay, from the lowest: compound 3; then compound 2; then compounds 4 and 1 (each within the scatter of the next).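

In this assay the series now has its first step in a single place: a 1.2-fold lower number from compound 1 to compound 4 (0.09 log units; within the scatter) and this step lies within the scatter. Trifluoromethyl and (trifluoromethyl)carbonyl on this aromatic carbon therefore cannot be told apart here, even though the entering group has 6 heavy atoms and 1 hydrogen-bond acceptor against 4 heavy atoms and 0 hydrogen-bond acceptors in the leaving group. Nothing measured bears on why the two groups read alike.

As far as these compounds go, compound 2 and compound 3 carry a nitro group at this carbon but also differ elsewhere, so the step that nitro would give on the core of compound 1 remains open. Also open, from the compounds shown here alone, is whether an amine or a carboxylic acid at this carbon would give a step beyond the scatter.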